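The source may report more compounds than this note shows. Statements on the series, on what has been measured and on what is new or still open speak of the compounds shown alone.

Measured so far:
compound 1, `COc1ncnc2c1c(-c1ccsc1)cn2[C@@H]1O[C@H](CO)[C@@H](O)[C@H]1O`: 5170 nM
compound 2, `C#Cc1cn([C@@H]2O[C@H](CO)[C@@H](O)[C@H]2O)c2ncnc(OC)c12`: 8160 nM

Both numbers come from a functional assay on A549 cells (Homo sapiens), read by MTT assay, with a stated time of 72 h; a higher number here means a weaker inhibitor, a lower number a stronger inhibitor. Among the compounds with values here, compound 2 holds the higher of the two numbers; its only neighbour is compound 1, and the step of a 1.6-fold higher number from compound 1 to compound 2 (0.20 log units; within the scatter) lies within the scatter, so the two compounds are not separated by this assay.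

Compound 3 `COc1ncnc2c1c(I)cn2[C@@H]1O[C@H](CO)[C@@H](O)[C@H]1O` is the next member of the series. It differs from compound 2 by iodo in place of ethynyl on an aromatic carbon. Within the data shown here, no measured step involves the iodo group. Among the measured compounds shown here, the only step available, a 1.6-fold higher number from compound 1 to compound 2 (0.20 log units; within the scatter), exchanges a different group at the same aromatic carbon and stays within the scatter, so the one exchange seen at this carbon has not moved this assay appreciably. On that basis no step beyond the scatter is expected from compound 2 to compound 3, although a single step is a thin foundation and the range is kept wide accordingly.

Compound 3 is expected to give about 8000 nM, with a range from 3000 nM to 22000 nM. The step this estimate implies is a 1.0-fold lower number from compound 2 to compound 3 (0.01 log units; within the scatter).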

Compound 3, half-maximal inhibitory concentration: > 20000 nM
Compound 3: only a limit was reported; the forecaster's own chance of this, stated with the estimate: 5%; at least 2.5-fold (0.39 log units) between middle value and limit.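

In this assay, this aromatic carbon, two ring bonds from the ring nitrogen, proves sensitive to the group it carries, which the earlier pair could not show: that exchange gave a 1.6-fold higher number from compound 1 to compound 2 (0.20 log units; within the scatter), whereas iodo in place of ethynyl gives an at least 2.4-fold higher number from compound 2 to compound 3 (0.38 log units; beyond the scatter), and iodo in place of thiophen-3-yl gives an at least 3.8-fold higher number from compound 1 to compound 3 (0.58 log units; beyond the scatter). Thiophen-3-yl and ethynyl remain unseparated from each other, so the finding among these three compounds is only that iodo stands apart from both, with the weaker reading in this assay, and size alone does not order them, since ethynyl, with few heavy atoms, stays with the larger thiophen-3-yl. For compound 3 only a limit is available, so both new steps give a minimum size and no more: the limit of > 20000 nM in this assay, at which 1 of the 3 values shown sits.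

Still open, from the compounds shown here alone, is how far compound 3 lies from the other two, and whether the effect belongs to iodo alone or extends to other halogens such as chloro or bromo. Going by these compounds, the response of this carbon to an amine, a carboxylic acid or a longer alkynyl chain also remains unknown.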